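Removing the acetoxy-hydroxy chain: cytotoxicity of compound 3

The compounds below may be only part of what the source reports. "The series", "measured", "known", "first", "only" and "open" are said of these compounds alone.

The series shares a core carrying an indole-like ring bonded to a dioxopiperazine unit, and all were tested in an ADME assay on MDCK cells (Canis lupus familiaris) for cytotoxicity, read by CellTiter-Glo, with a stated time of 40 h; on this read-out lower numbers stand for higher toxicity in this test and higher numbers for lower toxicity in this test. Compound 1, `C=CC(C)(C)c1[nH]c2ccc(C[C@H](OC(C)=O)C(C)(C)O)cc2c1/C=C1\NC(=O)[C@H](C)NC1=O`, gives > 200000 nM in this assay, which is a limit of the test rather than a number. Its companion compound 2, `C=CC(C)(C)c1[nH]c2ccc(C[C@H](OC(C)=O)C(C)(C)O)cc2c1C[C@@H]1NC(=O)[C@H](C)NC1=O`, gives > 200000 nM in this assay, again a limit. Within the data shown here, the only measured step, a step that the two limits leave unreadable from compound 1 to compound 2, therefore cannot be sized; both values sit at the limit of > 200000 nM in this assay, at which 2 of the 2 values shown sit. Compound 3, `C=CC(C)(C)c1[nH]c2ccc(CC=C(C)C)cc2c1/C=C1\NC(=O)[C@H](C)NC1=O`, differs from compound 1 by 2-methylprop-1-en-1-yl in place of 1-acetoxy-2-hydroxy-2-methylpropyl on a saturated chain carbon bound to an aromatic carbon. Among the measured compounds shown here, no measured step touches this part of the structure, so nothing in the data points to a change in either direction. Given that compound 1 sits at a limit, the step of a number no higher from compound 1 to compound 3 (the limit leaves the size open) is expected to stay within the usual scatter. Compound 3 is therefore estimated at 200000 nM, with a plausible range from 60000 nM to 400000 nM, and the test may well again report only a limit.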

Compound 3, half-maximal cytotoxic concentration: > 200000 nM
Compound 3 gave a limit, no number; the forecaster's own chance of this, stated with the estimate: 65%; the middle value lies on the limit itself.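

Compound 3 and compound 1 both give only a limit rather than a number in this assay, so the step between them cannot be read: the limit of > 200000 nM in this assay, at which 3 of the 3 values shown sit.

The compounds shown leave open whether 2-methylprop-1-en-1-yl in place of 1-acetoxy-2-hydroxy-2-methylpropyl changes the read-out, and what number any of the three compounds would give.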